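From compound 2 to compound 4: a 4-bromophenyl enters

The source may report more compounds than this note shows. Statements on the series, on what has been measured and on what is new or still open speak of the compounds shown alone.

Of the compounds shown here, three have been measured so far in a functional assay on DU-145 cells (Homo sapiens) for cytotoxicity, read by trypan blue exclusion, with a stated time of 96 h (a lower number here means a stronger inhibitor, a higher number a weaker inhibitor), and their numbers lie far apart. Compound 2 (`COC(=O)CNc1cc(CS(=O)(=O)/C=C/c2c(OC)cc(OC)cc2OC)ccc1OC`) gives 100 nM as the lowest of the three numbers. Compound 1 (`COc1ccc(N)cc1CS(=O)(=O)/C=C/c1c(OC)cccc1OC`) stands nearest with 25000 nM as its value, and compound 3 (`COC(=O)CNc1cc(CS(=O)(=O)/C=C/c2cc(OC)c(OC)c(OC)c2)ccc1OC`) lies furthest off with 75000 nM as its value, both gaps being beyond the scatter.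

Compound 4 (`COC(=O)C(Nc1cc(CS(=O)(=O)/C=C/c2c(OC)cc(OC)cc2OC)ccc1OC)c1ccc(Br)cc1`) has not yet been measured. In compound 4, 4-bromophenyl stands in place of hydrogen on a saturated chain carbon bound to a carbonyl carbon and a nitrogen on an aromatic ring, a difference that counts as 4-bromophenyl in place of hydrogen on a saturated chain carbon bound to a carbonyl carbon and a nitrogen on an aromatic ring in all. Going by the values given here, no measured pair isolates this change, so the data give no direct guide to its size. Compound 2 shares the (methoxycarbonyl)methyl group with compound 3, whose 75000 nM shows that carrying this group does not by itself secure a low number. A move toward a higher number, and so a weaker inhibitor, is therefore expected. The expected size is a 3.0-fold higher number from compound 2 to compound 4 (0.48 log units; beyond the scatter) as a moderate estimate with wide uncertainty. Compound 4 is estimated at 300 nM with an expected range from 40 nM to 4000 nM in this assay.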

Compound 4, half-maximal inhibitory concentration: 300 nM
Compound 4: the middle estimate sits on the measured number at the digits printed; low and high end bracket the measured number.
By their numbers in this assay, from the lowest: compound 2; then compound 4; then compound 1; then compound 3.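

Going by these compounds alone, replacing hydrogen with 4-bromophenyl on the saturated chain carbon bound to a carbonyl carbon and a nitrogen on an aromatic ring gives a 3.0-fold higher number from compound 2 to compound 4 (0.48 log units; beyond the scatter) in this assay, and this is the only pair so far that differs in one place. It gives this position its first direct reading: the change moves the number beyond the scatter, but the step is modest, and compound 4 still reads 300 nM despite the large group added at this carbon. Nothing on hand accounts for the direction or size of this step.

The compounds shown leave open whether the bromine or the ring carries the step, something a plain phenyl, a 4-methoxyphenyl or a simple methyl on the same carbon could separate, and whether the methyl ester matters, something a carboxylic acid or an amide in its place could test. They also leave open whether the same 4-bromophenyl change would give a step of similar size on the core of compound 3, which differs from compound 2 in the methoxy pattern of its second aromatic ring.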